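Lengthening the Sulfonyl Alkyl of a Compound at the Limit

The source may report more compounds than this note shows. Statements on the series, on what has been measured and on what is new or still open speak of the compounds shown alone.

Compound 1 `CS(=O)(=O)Nc1cccc2c1CCC2c1ncc[nH]1` was examined in a functional assay on CHO cells for agonist activity at Alpha-1B adrenergic receptor (Homo sapiens), read by FLIPR and calcium flux; a higher number here means that more compound is needed for the effect, a lower number that less compound is needed. In this assay compound 1 does not reach a measurable effect and stops at the limit of the assay, > 10000 nM, so no number is known for it. Among the measured compounds shown here, the single measured neighbour is compound 2 `Cc1ccc2c(c1NS(C)(=O)=O)CCC2c1ncc[nH]1`. In this assay compound 2 likewise stops at the limit of the assay, > 10000 nM. For the measured compounds named here, the step that the two limits leave unreadable from compound 1 to compound 2 therefore cannot be sized, and the only evidence on the measured steps is the limit of > 10000 nM in this assay, at which 2 of the 2 values shown sit.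

Compound 3 `CCS(=O)(=O)Nc1cccc2c1CCC2c1ncc[nH]1` differs from compound 1 by methyl in place of hydrogen on a saturated chain carbon bound to a sulfonyl sulfur, so that methanesulfonamido becomes (ethylsulfonyl)amino. Going by the values given here, no measured step touches a change of this kind, and the one step that exists has no readable size. With both measured values sitting at the limit, the expected outcome for compound 3 is that this assay most likely again reports only a limit, leaving any step from compound 1 unreadable. The estimate for compound 3 is 15000 nM, within the range 3000 nM to 100000 nM. This corresponds to an expected step that the limit leaves unreadable from compound 1 to compound 3.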

Compound 3, half-maximal effective concentration: > 10000 nM
Compound 3 was reported as a limit (the forecaster's own chance of this, stated with the estimate: 80%); the middle value is on the limit's open side.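

In this assay compound 3 stops at a limit of the assay (> 10000 nM), not at a number. Among the compounds shown here, compound 1 is also known only as a limit, so no step between compound 1 and compound 3 can be read. The compounds shown leave open whether any other change on the shared core would give a measurable value in this assay at all.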